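The source may hold more compounds than are shown below. What is called first, only, known or untested is meant among the compounds shown, and "the series" means these compounds.

Measured so far in a functional assay on SK-BR-3 cells (Homo sapiens) for antiproliferative activity, read by MTT assay, with a stated time of 72 h; a higher number here means a weaker inhibitor, a lower number a stronger inhibitor:
- compound 1 `CCN1CCN(c2cc(C)c3cc(NC(=O)c4ccc[nH]4)ccc3n2)CC1`: 13200 nM
- compound 2 `CCN1CCN(c2cc(C)c3cc(NC(=O)c4ccccc4F)ccc3n2)CC1`: 38100 nM
- compound 3 `Cc1cc(N(C)C)nc2ccc(NC(=O)c3ccc(Cl)c(Cl)c3)cc12`: > 50000 nM

In this assay compound 3 reads > 50000 nM, which is a limit and not a number. Compound 4 `Cc1cc(NCCN2CCCCC2)nc2ccc(NC(=O)c3ccc(Cl)c(Cl)c3)cc12` keeps the rest of compound 3 and changes one group, with (2-(piperidin-1-yl)ethyl)amino in place of dimethylamino on an aromatic carbon, next to the ring nitrogen: (2-(piperidin-1-yl)ethyl)amino in place of dimethylamino on an aromatic carbon.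

Among the measured compounds shown here, no measured step touches this place. For the measured compounds named here, the only measured step, a 2.9-fold higher number from compound 1 to compound 2 (0.46 log units; beyond the scatter), lies on the carbonyl side. It is modest but beyond the scatter, so it offers a sense of scale and no direct guide to this change.

Compound 1 at 13200 nM and compound 2 at 38100 nM give more indirect support. Both carry a group other than dimethylamino at the changing place and both return numbers, though they also differ from compound 3 at the carbonyl. On that basis, a modest move toward a lower number is expected, and compound 4 could still stay at the limit.

The expected change is an at least 2.7-fold lower number from compound 3 to compound 4 (0.44 log units; beyond the scatter), an estimate that starts from a limit. Compound 4 is estimated at 18000 nM, with an expected range from 5000 nM to 50000 nM.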

Compound 4, half-maximal inhibitory concentration: 1800 nM
Estimate against measurement, compound 4: 10-fold (1.00 log units) above; measured number outside the range, below it.
By their numbers in this assay, from the lowest: compound 4; then compound 1; then compound 2. At a limit, above all of these: compound 3.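

In this assay, exchanging the dimethylamino group next to the ring nitrogen for (2-(piperidin-1-yl)ethyl)amino, with the rest of the molecule unchanged, gives an at least 27-fold lower number from compound 3 to compound 4 (1.44 log units; beyond the scatter). Among the compounds shown here, the earlier compounds offered only a step on the carbonyl side, a 2.9-fold higher number from compound 1 to compound 2 (0.46 log units; beyond the scatter), so this is the first measured sign that the group at this place can shift the reading by a large step. Compound 3 stands at a limit and not at a number, so the step gives only a lower bound on the size of the change: the limit of > 50000 nM in this assay, at which 1 of the 4 values shown sits.

The compounds shown do not separate the contributions of the piperidine ring, the ethyl chain and the added hydrogen-bond donor, and they leave open what a morpholine ring or a longer chain in place of the ethyl chain would give. From the compounds shown here alone, compound 1 and compound 2 differ from compound 4 both at this place and on the carbonyl side, so it also remains open whether the same change would give a step of similar size with their carbonyl groups.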